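E to Z double bond change in compound 1

The source may report more compounds than this note shows. Statements on the series, on what has been measured and on what is new or still open speak of the compounds shown alone.

Measured so far in a physicochemical assay for lipophilicity, measured as octanol-water partition; on this read-out higher numbers stand for higher lipophilicity and lower numbers for lower lipophilicity:
- compound 1 `CC(C)=CCC/C(C)=C/CC/C(C)=C/Cn1cc(-c2ccccc2)nn1` gives 6.95
- compound 2 `CCCc1cn(C/C=C(/C)CCC=C(C)C)nn1` gives 4.05

Of these two numbers compound 1 holds the higher, and the gap down to compound 2 lies beyond the scatter. Compound 3 `CC(C)=CCC/C(C)=C/CC/C(C)=C\Cn1cc(-c2ccccc2)nn1` is not yet measured. Its relation to compound 1 is the two compounds have the same atoms and bonds and differ only in configuration as drawn: 1 of 2 stereo elements differ; a double bond is drawn E in compound 1 and Z in compound 3, so that a double bond is drawn E in compound 1 and Z in compound 3. Going by the values given here, no measured pair shows such a change, so the size rests on expectation alone, and no shift beyond the scatter in this assay is expected. The expected a number 0.05 log units lower from compound 1 to compound 3 (within the scatter) is small and has no firm direction. For compound 3 the estimated value is 6.9 with an expected range from 6.5 to 7.3.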

Compound 3, partition coefficient: 6.95
For compound 3 the middle estimate is 0.05 log units below the measured one; the range from low to high includes it.
By their numbers in this assay, from the lowest: compound 2; then compounds 1 and 3 (each within the scatter of the next).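

The pair isolates a single structural variable, which the two earlier compounds did not offer: the fact that compounds 1 and 3 differ only in the configuration as drawn. Going from E to Z at this double bond gives, in this assay, no change at the digits printed from compound 1 to compound 3 (within the scatter). At this position, the read-out therefore does not separate the two drawn configurations on the long chain shared by this pair.

As far as these compounds go, whether the E to Z change stays equally silent on the shorter chain of compound 2 remains open. The same question stands for analogues carrying a carboxylic acid or an amine on the shared core.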